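Swapping the thioether aryl group in a growth-inhibition series

This account rests on a few compounds, and the source may have more. Where it says the series, first, only, none or still open, it means among the compounds named here.

Measured so far:
Compound 1, `Nc1ccccc1NC(=O)c1ccc(CSc2ccc(Br)cc2)cc1`: in a functional assay on HCT-116 cells (Homo sapiens) for inhibition, read by CCK-8 assay, with a stated time of 72 h, tested at 2 uM (a higher number here means more inhibition of growth at the concentration tested, a lower number less inhibition of growth), compound 1 gives 9.96%.
Compound 2, `Nc1ccccc1NC(=O)/C=C/c1ccc(CSc2ccc(F)cc2)cc1`: in this assay compound 2 gives 14.1%.

Among the compounds with values here, only two compounds have been measured. Compound 2 holds the higher of the two numbers in this assay, but its gap to compound 1 lies within the scatter, so the two cannot be set apart, and both sit low in this assay. Within the data shown here, no pair of measured compounds differs in a single place, so nothing is yet known about what any one change does to the read-out.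

Compound 3, `Cc1cc(C)cc(SCc2ccc(/C=C/C(=O)Nc3ccccc3N)cc2)c1`, remains to be measured. It differs from compound 2 in one place: 3,5-dimethylphenyl in place of 4-fluorophenyl on a sulfur. Among the measured compounds shown here, with no measured step of this kind to lean on, and with both known values low, the expectation rests on the assumption that a change at the aryl group on the sulfur moves the number only modestly. The step of a number 1.9 percentage points higher from compound 2 to compound 3 (within the scatter) is therefore expected to be small, not clearly beyond the scatter, in either direction. Compound 3 is estimated at 16%, with a range from 4% to 32%.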

Compound 3, percent growth inhibition at one concentration: 7.98%
For compound 3 the middle estimate is 8 percentage points above the measured one; the range from low to high includes it.
By their numbers in this assay, from the lowest: compounds 3, 1 and 2 (each within the scatter of the next).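

In this assay, within the data shown here, exchanging the 4-fluorophenyl group on the sulfur for a 3,5-dimethylphenyl group gives a number 6.1 percentage points lower from compound 2 to compound 3 (within the scatter), the first step that isolates a single change. At this position, then, the exchange of one carbon-only aromatic ring for another, with no hydrogen-bond donors or acceptors on either group and no net charge, does not produce a difference that can be told from the scatter. No measurement is available that could explain this reading.

The compounds shown leave open whether a group of another kind on the sulfur, such as an aryl ring carrying an amine or a carboxylic acid, or a longer saturated chain in place of the aryl group, would move the number beyond the scatter. Compound 1 differs from compound 2 and compound 3 in more than one place, so the separate contributions of the part between the amide carbonyl and the ring and of the aryl group on the sulfur also remain unresolved.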